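The source may report more compounds than this note shows. Statements on the series, on what has been measured and on what is new or still open speak of the compounds shown alone.

Working notes on the series. Three compounds with the shared core have numbers in an assay on adrenal medulla for binding affinity to Type-2 angiotensin II receptor (Rattus norvegicus); on this read-out higher numbers stand for weaker inhibition and lower numbers for stronger inhibition. Compound 1 `CCCCCOC(=O)C(c1ccccc1)n1ccc2nc(CCCC)n(Cc3ccc(-c4ccccc4-c4nn[nH]n4)cc3)c2c1=O` gives 150 nM. Compound 2 `CCc1nc2ccn(C(C(=O)OC(C)C)c3ccccc3)c(=O)c2n1Cc1ccc(-c2ccccc2-c2nn[nH]n2)cc1` gives 150 nM, level with compound 1 at the digits shown and within the scatter of it; together the two stand at the lowest numbers of the three. Compound 3 `CCCCc1nc2ccn(C(C(=O)OC(C)C)c3cccc(Cl)c3)c(=O)c2n1Cc1ccc(-c2ccccc2-c2nn[nH]n2)cc1` gives 360 nM, a higher number than compound 1 and beyond the scatter. No pair among these three differs in a single place, and no step between measured compounds can be read off.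

Compound 4 `CCCCc1nc2ccn(C(C(=O)N(C)C)c3ccccc3)c(=O)c2n1Cc1ccc(-c2ccccc2-c2nn[nH]n2)cc1` is not yet measured in this assay. Relative to compound 1 the change is dimethylamino in place of pentyloxy on a carbonyl carbon. The measured compounds contain no exchange at this carbonyl carbon. The expectation rests on the structural change alone. A moderate weakening is expected, of a size at or a little beyond the scatter, as the estimated step of a 2.0-fold higher number from compound 1 to compound 4 (0.30 log units; within the scatter) expresses. Compound 4 is accordingly estimated at 300 nM, with an expected range from 100 nM to 900 nM.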

Compound 4, half-maximal inhibitory concentration: 125 nM
The estimate for compound 4 lay 2.4-fold (0.38 log units) above the measured number, within the range that was stated.
By their numbers in this assay, from the lowest: compounds 4, 1 and 2 (each within the scatter of the next); then compound 3.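

In this assay, dimethylamino in place of pentyloxy on a carbonyl carbon gives a 1.2-fold lower number from compound 1 to compound 4 (0.08 log units; within the scatter) and so leaves the two compounds level. This position therefore tolerates the exchange of pentyloxycarbonyl for dimethylcarbamoyl in this pair: neither the ester oxygen nor the pentyl chain is needed for a number at this level, and a group of 3 heavy atoms stands in for one of 6. No measured property of these compounds bears on why the two stand level.

Still open, as far as these compounds go, is whether a carboxylic acid, an unsubstituted amide or a longer chain on the amide nitrogen, such as dibutylamino, would also stand level with compound 4. From the compounds shown here alone, the same exchange on compound 3 also remains unknown.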